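Methyl position shift on the terminal aryl group

The compounds below may be only part of what the source reports. "The series", "measured", "known", "first", "only" and "open" are said of these compounds alone.

Compound 3 `Cc1cccc(-c2nnc(CSc3nnc(/N=C/c4ccccc4O)s3)o2)c1` gives 11600 nM in a functional assay on MCF7 cells (Homo sapiens) for inhibition, read by CCK-8 assay (a lower number here means a stronger inhibitor, a higher number a weaker inhibitor), the highest of the three numbers, though the neighbours lie within the scatter: compound 1 `Oc1ccccc1/C=N/c1nnc(SCc2nnc(-c3ccccc3Br)o2)s1` gives 9140 nM and compound 2 `Oc1ccccc1/C=N/c1nnc(SCc2nnc(-c3ccc(Br)cc3)o2)s1` gives 8320 nM. Compound 4 `Cc1ccc(-c2nnc(CSc3nnc(/N=C/c4ccccc4O)s3)o2)cc1` differs from compound 3 by 4-methylphenyl in place of 3-methylphenyl on an aromatic carbon. The measured steps that bear on this change are the aryl exchanges at the same place: a 1.1-fold lower number from compound 1 to compound 2 (0.04 log units; within the scatter), a 1.3-fold higher number from compound 1 to compound 3 (0.10 log units; within the scatter) and a 1.4-fold higher number from compound 2 to compound 3 (0.14 log units; within the scatter), none of them beyond the scatter. A further aryl exchange at this place is therefore expected to give no step beyond the scatter in this assay. Compound 4 is expected at 10000 nM, with a range of 5000 nM to 20000 nM, a step of a 1.2-fold lower number from compound 3 to compound 4 (0.06 log units; within the scatter) expected from compound 3.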

Compound 4, half-maximal inhibitory concentration: 8750 nM
For compound 4 the middle estimate is 1.1-fold (0.06 log units) above the measured one; the measured number falls inside the stated range.
By their numbers in this assay, from the lowest: compounds 2, 4, 1 and 3 (each within the scatter of the next).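

Moving the methyl from 3-methylphenyl to 4-methylphenyl stays within the scatter in this assay, a 1.3-fold lower number from compound 3 to compound 4 (0.12 log units; within the scatter). The exchange of bromo for methyl, a 1.1-fold higher number from compound 2 to compound 4 (0.02 log units; within the scatter), and of 2-bromophenyl for 4-methylphenyl, a 1.0-fold lower number from compound 1 to compound 4 (0.02 log units; within the scatter), also stay within the scatter, so neither methyl placement nor the choice between methyl and bromo separates these four compounds. Nothing available explains this flat response. Open, on these data alone, is whether an amine, a carboxylic acid or a longer chain on the terminal aryl group would give a step beyond the scatter.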